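Amino for Chloro on the Purine Core of a Benzyl Chloride

This account rests on a few compounds, and the source may have more. Where it says the series, first, only, none or still open, it means among the compounds named here.

compound 1 `ClCc1ccccc1Cn1cnc2c(Cl)nc(Cl)nc21` — 4780 nM
compound 2 `ClCc1ccc(Cn2cnc3c(Cl)nc(Cl)nc32)cc1` — 7590 nM

In a functional assay on HCT-15 cells (Homo sapiens) for cytotoxicity, read by sulforhodamine B assay, with a stated time of 48 h (a lower number here means that less compound is tolerated, a higher number that more compound is tolerated), compound 1 gives 4780 nM, the lowest of the two numbers. Compound 2 gives 7590 nM, a gap within the scatter, so the two cannot be ordered. Compound 3 `Nc1nc(Cl)c2ncn(Cc3ccccc3CCl)c2n1` is still to be measured. It differs from compound 1 by amino in place of chloro on an aromatic carbon. For the measured compounds named here, no measured pair shows this change, so its size is open; a modest rise in the number, at most somewhat beyond the scatter, seems the likelier outcome. Compound 3 is expected near 7500 nM, within 2500 nM to 22000 nM. The expected step is a 1.6-fold higher number from compound 1 to compound 3 (0.20 log units; within the scatter).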

Compound 3, concentration lethal to 50% of the cells: > 100000 nM
Compound 3: no number, only a limit (the forecaster's own chance of this, stated with the estimate: 5%); at least 13-fold (1.12 log units) between middle value and limit.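

For the compounds shown here, compound 1 and compound 2 held no change on this carbon, so this is the first reading of the position, and the swap of chloro for amino between two ring nitrogen atoms proves far from neutral in this assay: an at least 20-fold higher number from compound 1 to compound 3 (1.32 log units; beyond the scatter). As far as these compounds go, compound 3 gives > 100000 nM, which is a limit of the assay and not a number, so the full size of the step stays unknown: the limit of > 100000 nM in this assay, at which 1 of the 3 values shown sits.

From the compounds shown here alone, whether a methylamino or a methoxy group on this carbon would behave like amino remains open. So does the effect of amino on the core of compound 2.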